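Swapping an amide for a benzyl arm on a bile acid receptor agonist

The source may report more compounds than this note shows. Statements on the series, on what has been measured and on what is new or still open speak of the compounds shown alone.

Measured compounds:
- compound 1, `CC(C)c1onc(-c2c(Cl)cccc2Cl)c1COc1ccc(N(C)C(=O)c2ccc(C(=O)O)cc2)c(C(F)(F)F)n1`: 63%
- compound 2, `Cc1cc(OCc2c(-c3c(Cl)cccc3Cl)noc2C(C)C)ncc1[N+](=O)[O-]`: 76%

In a functional assay on HEK293 cells for agonist activity at Bile acid receptor (Homo sapiens), read by a luciferase reporter (on this read-out lower numbers stand for smaller maximal responses and higher numbers for larger maximal responses), compound 1 gives 63%, the lowest of the two numbers. Compound 2, built on a different scaffold, gives 76% in this assay, a value that sits beyond the usual scatter above compound 1. For the measured compounds named here, no single-change pair among the measured compounds exists, so the size of any step must be guessed rather than read off.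

Compound 3, `CC(C)c1onc(-c2c(Cl)cccc2Cl)c1COc1ccc(N(C)Cc2ccc(OCC(=O)O)cc2)c(C(F)(F)F)n1`, has not yet been measured in this assay. It departs from compound 1 at one place: 4-(carboxymethoxy)benzyl in place of (4-carboxyphenyl)carbonyl on a nitrogen on an aromatic ring. The carbonyl that tied the aromatic ring to the nitrogen is gone, and the acid is now carried on a short chain attached through oxygen.

Going by the values given here, with no comparable step available, the expectation for the move from compound 1 to compound 3 is a change of modest size, a number 2 percentage points higher from compound 1 to compound 3 (within the scatter), with no firm direction. Compound 3 is therefore expected to reach about 65% in this assay, within a range from 40% to 90%.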

Compound 3, largest response reached (reported as efficacy), in percent of the reference or control that the assay uses: 59%
Estimate against measurement, compound 3: 6 percentage points above; low and high end bracket the measured number.
By their numbers in this assay, from the lowest: compounds 3 and 1 (each within the scatter of the next); then compound 2.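

In this assay, putting 4-(carboxymethoxy)benzyl in place of (4-carboxyphenyl)carbonyl on the nitrogen gives a number 4 percentage points lower from compound 1 to compound 3 (within the scatter). This position on the shared core therefore accepts an arm without the carbonyl and with the acid on a short chain attached through oxygen, and the maximal responses of the two compounds cannot be told apart. Nothing shown here accounts for this result.

On these data alone, the step changes two things at once, the link to the nitrogen and the way the acid is attached, so the share of each remains unknown and either could matter when taken alone. As far as these compounds go, it also remains open how this arm would respond if a nitrile or an amine took the place of the carboxylic acid, or if a longer chain carried the acid.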